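A few compounds are considered here, and "the series" means these few. Any claim that something is new, unique, unknown or untested is made for them only; others in the source may bear on it.

Working notes on the aryl sulfonate series, read in a functional assay on MCF7 cells (Homo sapiens) for antiproliferative activity, read by sulforhodamine B assay, with a stated time of 48 h; a higher number here means a weaker inhibitor, a lower number a stronger inhibitor.

Compound 1 `CCCN1CCN(c2ccc(S(=O)(=O)Oc3ccccc3C)cc2)C1=O` gives in this assay only a limit, > 100000 nM, which is the limit of > 100000 nM in this assay, at which 1 of the 3 values shown sits. Compound 2 `CCCN1CCN(c2ccc(S(=O)(=O)Oc3ccccc3OC)cc2)C1=O` gives in this assay 13000 nM. Compound 3 `CCCN1CCN(c2ccc(S(=O)(=O)Oc3ccc(C)cc3)cc2)C1=O` gives in this assay 64000 nM. Among the two numbers, compound 3 sits highest, and the one number nearest to it is that of compound 2.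

The step of an at least 7.6-fold lower number from compound 1 to compound 2 (0.88 log units; beyond the scatter) is the largest measured one; the change is methoxy in place of methyl on an aromatic carbon. The step of an at least 1.5-fold lower number from compound 1 to compound 3 (0.19 log units; that floor lies within the scatter) rests on a limit; the change is 4-methylphenyl in place of 2-methylphenyl on an oxygen. The step of a 4.9-fold higher number from compound 2 to compound 3 (0.69 log units; beyond the scatter) goes to a higher number.

Compound 4 `CCCN1CCN(c2ccc(S(=O)(=O)Oc3ccc(OC)cc3)cc2)C1=O` has not yet been measured in this assay. It differs from compound 3 by methoxy in place of methyl on an aromatic carbon. This is the same kind of change as that from compound 1 to compound 2, but not the same: there the methoxy stands ortho to a large group, here para to a large group. How the two cores differ is given by 4-methylphenyl in place of 2-methylphenyl on an oxygen.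

Because the step of an at least 7.6-fold lower number from compound 1 to compound 2 (0.88 log units; beyond the scatter) was at least modest, a lowering of similar size is expected here, with the reservation that the earlier step starts from a limit and the place differs. The expected step is a 5.3-fold lower number from compound 3 to compound 4 (0.73 log units; beyond the scatter). For compound 4 the estimate in this assay is 12000 nM, expected to lie between 3000 nM and 50000 nM.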

Compound 4, half-maximal inhibitory concentration: 20000 nM
For compound 4 the middle estimate is 1.7-fold (0.22 log units) below the measured one, and the stated range covers the measured number.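

In this assay, methoxy in place of methyl on an aromatic carbon, para to a large group, gives a 3.2-fold lower number from compound 3 to compound 4 (0.51 log units; beyond the scatter), which shows a lowering in the same direction on both cores but fixes no common size for the change, and this holds for these two pairs only: the same change on two cores in this assay, an at least 7.6-fold lower number (0.88 log units; beyond the scatter) from compound 1 to compound 2 and a 3.2-fold lower number (0.51 log units; beyond the scatter) from compound 3 to compound 4; the limit leaves it open whether they differ

With methoxy on both compounds, a 1.5-fold higher number from compound 2 to compound 4 (0.19 log units; within the scatter), so 2-methoxyphenyl and 4-methoxyphenyl on the oxygen are not separated in this assay, and the series gives no sign here that the place of the methoxy matters once methoxy is present. The remaining step, an at least 5.0-fold lower number from compound 1 to compound 4 (0.69 log units; beyond the scatter), starts from a limit and gives only a floor: the limit of > 100000 nM in this assay, at which 1 of the 4 values shown sits.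

The compounds shown hold only methyl and methoxy on this ring, so it stays open whether the lowering extends to other groups in the same place, such as chlorine, a nitrile, an amine or a carboxylic acid. Also open, from the compounds shown here alone, is whether the change behaves alike on a core with a longer chain in place of the one on the shared core, and whether it holds in any other cell line.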